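The compounds below may be only part of what the source reports. "The series", "measured", "known", "first", "only" and "open" are said of these compounds alone.

Working notes on the series.

Compound 1 `C[C@@H](O[C@H]1CN2C(=O)C=C(c3ccc(C#N)cc3)CC2[C@@H]1c1ccc(F)cc1)c1cc(C(F)(F)F)cc(C(F)(F)F)c1` is the reference point. Among the compounds with values here, in an assay on CHO cells for displacement of a labelled ligand from Substance-P receptor (Homo sapiens) (on this read-out higher numbers stand for weaker inhibition and lower numbers for stronger inhibition), compound 1 gives 1.8 nM, the highest of the three numbers measured so far. Compound 2 `C[C@@H](O[C@H]1CN2C(=O)C=C(c3ccc(NS(C)(=O)=O)cc3)CC2[C@@H]1c1ccc(F)cc1)c1cc(C(F)(F)F)cc(C(F)(F)F)c1` carries methanesulfonamido in place of cyano on the aromatic carbon; in this assay compound 2 gives 1 nM, and the step is a 1.8-fold lower number from compound 1 to compound 2 (0.26 log units; within the scatter). Compound 3 `C[C@@H](O[C@H]1CN2C(=O)C=C(c3ccc(CO)cc3)CC2[C@@H]1c1ccc(F)cc1)c1cc(C(F)(F)F)cc(C(F)(F)F)c1` carries hydroxymethyl at the same position; in this assay compound 3 gives 0.39 nM, a step of a 4.6-fold lower number from compound 1 to compound 3 (0.66 log units; beyond the scatter), while the step of a 2.6-fold lower number from compound 2 to compound 3 (0.41 log units; beyond the scatter) separates the two replacements.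

Compound 4 `C[C@@H](O[C@H]1CN2C(=O)C=C(c3cc[n+]([O-])cc3)CC2[C@@H]1c1ccc(F)cc1)c1cc(C(F)(F)F)cc(C(F)(F)F)c1` is not yet measured. The change from compound 1 is a group of 7 heavy atoms (5 carbon, 1 nitrogen, 1 oxygen; one six-membered aromatic ring with 1 hetero atom) in place of a group of 8 heavy atoms (7 carbon, 1 nitrogen; one six-membered aromatic ring of carbon only), on a double-bonded ring carbon. Here the whole 4-cyanophenyl leaves and a ring with one hetero atom enters, so the two measured steps, which only exchange the substituent on the phenyl, bear on it loosely: both replace cyano and both lower the number, one within the scatter and one modestly beyond it. For compound 4 the expectation is therefore a small step, most likely none beyond the scatter, possibly a slightly lower number, giving a 1.2-fold lower number from compound 1 to compound 4 (0.08 log units; within the scatter). The estimate for compound 4 in this assay is 1.5 nM, with a range from 0.5 nM to 4.5 nM.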

Compound 4, half-maximal inhibitory concentration: 0.1 nM
Estimate against measurement, compound 4: 15-fold (1.18 log units) above; the whole stated range lies above it.
By their numbers in this assay, from the lowest: compound 4; then compound 3; then compounds 2 and 1 (each within the scatter of the next).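

Within the data shown here, exchanging the whole 4-cyanophenyl on the double-bonded ring carbon, rather than only the substituent on the phenyl, gives in this assay the largest step so far, an 18-fold lower number from compound 1 to compound 4 (1.26 log units; beyond the scatter), and it is the only one printed as large. Among these compounds, the six-membered aromatic ring with 1 hetero atom also goes beyond both carbon-only rings that had replaced cyano on the phenyl, with a 3.9-fold lower number from compound 3 to compound 4 (0.59 log units; beyond the scatter), the best of the earlier compounds, and with a 10-fold lower number from compound 2 to compound 4 (1.00 log units; beyond the scatter) as well. This position therefore tolerates loss of the carbon-only aromatic ring, and the identity of the ring itself moves the number further than the substituent exchanges did. No measurement shown gives a reason for the size of this step.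

Open, going by these compounds, is whether the oxygen on the ring nitrogen is needed, which a plain pyridyl ring would test, and whether a hydroxymethyl or methanesulfonamido group on the new ring would add to the gain. Also open, on these data alone, is how an amine or a carboxylic acid on the phenyl would compare with the hydroxymethyl of compound 3.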